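A few compounds are considered here, and "the series" means these few. Any claim that something is new, unique, unknown or untested is made for them only; others in the source may bear on it.

Compound 1 `COc1ccc2[nH]c(-c3ccc[nH]3)c(C3CC(=O)NC3=O)c2c1`: 15000 nM
Compound 2 `COc1ccc2[nH]c(-c3ccc[nH]3)cc2c1`: 43000 nM
Compound 3 `O=C1NC(=O)c2c1c1[nH]ncc1c1[nH]c3ccccc3c21`: > 100000 nM

All three values come from a functional assay on U-373MG ATCC cells (Homo sapiens) for cytotoxicity, read by MTT assay, with a stated time of 72 h; on this read-out higher numbers stand for weaker inhibition and lower numbers for stronger inhibition. Compound 1 has the lower of the two exact numbers. The entry for compound 3 is a limit, not a number.

Compound 4 `Cc1ccc2[nH]c(-c3ccc[nH]3)c(C3CC(=O)NC3=O)c2c1` carries methyl in place of methoxy on an aromatic carbon of the core of compound 1 (methyl in place of methoxy on an aromatic carbon). For the measured compounds named here, the only measured step, a 2.9-fold higher number from compound 1 to compound 2 (0.46 log units; beyond the scatter), is modest and replaces the 2,5-dioxopyrrolidin-3-yl group with hydrogen, so it does not test this change. Going by the values given here, no measured step touches the methoxy group, so no shift beyond the scatter is expected in either direction. The expected step is no change at the digits printed from compound 1 to compound 4 (within the scatter). For compound 4 the estimated value is 15000 nM, with an expected range from 6000 nM to 38000 nM.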

Compound 4, half-maximal inhibitory concentration: 5000 nM
The estimate for compound 4 lay 3.0-fold (0.48 log units) above the measured number; the whole stated range lies above it.
By their numbers in this assay, from the lowest: compound 4; then compound 1; then compound 2. At a limit, above all of these: compound 3.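

The earlier compounds shown here varied only the 2,5-dioxopyrrolidin-3-yl group, leaving the methoxy position untested. In this assay, methyl in place of methoxy gives a 3.0-fold lower number from compound 1 to compound 4 (0.48 log units; beyond the scatter) and so shows that this position affects the read-out and that the methoxy oxygen is not needed to keep the number this low. No measured property shown here accounts for the shift.

On these data alone, whether an amine, chlorine or a longer chain at this position would lower the number further remains open. So does whether methyl would give a similar step in compound 2, which lacks the 2,5-dioxopyrrolidin-3-yl group.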